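Azole variation at the branched chain: microsomal half-life

This account rests on a few compounds, and the source may have more. Where it says the series, first, only, none or still open, it means among the compounds named here.

Measured compounds in an ADME assay on microsomes from liver (Mus musculus) for metabolic stability; a higher number here means that the compound lasts longer, a lower number that the compound disappears faster:
compound 1 `CC(C)C(Cc1nnn[nH]1)c1ccc(-c2ccc3cccc(F)c3c2)[nH]c1=O`: 0.853 h
compound 2 `CC(C)C(Nc1nnc[nH]1)c1ccc(-c2ccc3cccc(F)c3c2)[nH]c1=O`: 2.42 h
compound 3 `Cc1c[nH]c(C(c2ccc(-c3ccc4cccc(F)c4c3)[nH]c2=O)C(C)C)n1`: < 0.0667 h

Compound 3 sits at the lower end of the three. Its result in this assay is a limit of the assay and not a number, as noted in the limit of < 0.0667 h in this assay, at which 1 of the 3 values shown sits. Compound 4 `CC(C)C(Cc1nnc[nH]1)c1ccc(-c2ccc3cccc(F)c3c2)[nH]c1=O` has not been measured in this assay. Its change from compound 3 is (4H-1,2,4-triazol-3-yl)methyl in place of 4-methyl-1H-imidazol-2-yl on a saturated chain carbon bound to an aromatic carbon and a saturated chain carbon.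

Among the measured compounds shown here, no measured step matches this change directly. The nearest are an at least 12-fold lower number from compound 1 to compound 3 (1.10 log units; beyond the scatter) and an at least 36-fold lower number from compound 2 to compound 3 (1.55 log units; beyond the scatter), both large, and both with the 4-methyl-1H-imidazol-2-yl compound at the low end. Compound 4 carries the (4H-1,2,4-triazol-3-yl) ring of compound 2 on the methyl linker of compound 1, so its half-life is expected to fall near those two compounds, and the step is expected to be large upward: an at least 17-fold higher number from compound 3 to compound 4 (1.25 log units; beyond the scatter). On that basis compound 4 is estimated at 1.2 h in this assay, with a range from 0.45 h to 3 h.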

Compound 4, half-life in the Mus musculus assay: < 0.0667 h
Compound 4: only a limit was reported; the forecaster's own chance of this, stated with the estimate: 10%; middle value at least 17-fold (1.25 log units) from the limit.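

In the Mus musculus assay, compound 4 gives a limit and not a number, the same one as compound 3: the limit of < 0.0667 h in the Mus musculus assay, at which 2 of the 4 values shown sit.

With the methyl linker kept, the ring change in the Mus musculus assay gives an at least 12-fold lower number from compound 1 to compound 4 (1.10 log units; beyond the scatter), and with the ring kept, the linker change gives an at least 36-fold lower number from compound 2 to compound 4 (1.55 log units; beyond the scatter), so at this position neither the triazole ring alone nor the methyl linker alone sets the result; the step from compound 3 to compound 4 cannot be read. In a physicochemical assay for solubility, in phosphate buffer, measured as kinetic solubility (a lower number here means a less soluble compound, a higher number a more soluble compound), compound 3 gives 15200 nM and compound 4 gives 24200 nM, which is a 1.6-fold higher number from compound 3 to compound 4 (0.20 log units; within the scatter).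

Open, as far as these compounds go, is how (1H-tetrazol-5-yl)amino or (4-methyl-1H-imidazol-2-yl)amino would behave at this chain carbon, which would show whether the amino linker holds up with other rings. Also open, from the compounds shown here alone, is whether a carboxylic acid or a longer chain could stand in for the azole.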